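This account rests on a few compounds, and the source may have more. Where it says the series, first, only, none or still open, it means among the compounds named here.

Working notes on the series, agonist response.

Of the compounds shown here, three have numbers so far. Compound 1 `Cc1c(OCC2=NCCN2)ccc(Cl)c1NS(C)(=O)=O` gives 60% in a functional assay on CHO cells for agonist activity at Alpha-1A adrenergic receptor (Homo sapiens), read by FLIPR and calcium flux; on this read-out lower numbers stand for smaller maximal responses and higher numbers for larger maximal responses. Compound 2 `COc1cccc2c1CCC2c1ncc[nH]1` gives 65% in this assay. Compound 3 `CCS(=O)(=O)Nc1cccc(Cc2c[nH]cn2)c1` gives 96% in this assay. Among these three numbers compound 2 stands second highest; its nearest neighbour is compound 1, whose number lies within the scatter of that of compound 2, and its furthest is compound 3, whose number is higher by an amount beyond the scatter. Within the data shown here, no pair of measured compounds differs in one place only, so no single step within this set is known.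

Compound 4 `c1cc(-c2ncco2)c2c(c1)C(c1ncc[nH]1)CC2` is not yet measured. It differs from compound 2 by 1,3-oxazol-2-yl in place of methoxy on an aromatic carbon. Among the measured compounds shown here, the measured set holds no pair carrying this exchange, and the three measured compounds differ from one another in several places at once, so their numbers offer no step to borrow. For this assay the expectation is a step from compound 2 to compound 4 no larger than the scatter, with no ground for a gain or a loss beyond it. The step estimated is a number 3 percentage points higher from compound 2 to compound 4 (within the scatter). Compound 4 is estimated at 68%, in a range from 48% to 88%.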

Compound 4, largest response reached (Emax), in percent of the reference or control that the assay uses: 63%
Compound 4: the middle estimate sits 5 percentage points above what was measured; measured number inside the range.
By their numbers in this assay, from the lowest: compounds 1, 4 and 2 (each within the scatter of the next); then compound 3.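

In this assay, among these compounds, the exchange of methoxy for 1,3-oxazol-2-yl on the aromatic carbon, ortho to a fused ring and meta to a fused ring, gives the only single step known so far: a number 2 percentage points lower from compound 2 to compound 4 (within the scatter). The maximal response therefore does not separate the two compounds at this position, even though the entering group has 5 heavy atoms and a five-membered aromatic ring with 2 hetero atoms, while the leaving group has 2 heavy atoms and no ring. Nothing on hand offers an explanation for this result.

What the shown compounds leave open is whether this position would tolerate groups of a different kind, such as an amine, a carboxylic acid or a longer alkyl chain, with the maximal response again staying within the scatter. From the compounds shown here alone, it also remains open whether the same exchange would give a similarly small step on a different core, since this single pair speaks only for the core shared by compound 2 and compound 4.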